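Triazolylmethyl for dimethylaminomethyl on a chloropyridine sulfonamide

A few compounds are considered here, and "the series" means these few. Any claim that something is new, unique, unknown or untested is made for them only; others in the source may bear on it.

Measured compounds:
compound 1, `COc1ncc(-c2ccc3nccc(-c4ccc(CN5CCCCC5)cc4)c3c2)cc1NS(=O)(=O)c1ccc(F)cc1F`: "not determined" (no result reported)
compound 2, `COc1ncc(-c2ccc3nccc(-c4ccc(Cn5cncn5)cc4)c3c2)cc1NS(=O)(=O)c1ccc(F)cc1F`: "not determined" (no result reported)
compound 3, `CN(C)Cc1ccc(-c2ccnc3ccc(-c4cnc(Cl)c(NS(=O)(=O)c5ccc(F)cc5F)c4)cc23)cc1`: 53 nM

Three compounds were examined in a functional assay on MDA-MB-231 cells (Homo sapiens) for cytotoxicity, read by MTT assay, with a stated time of 72 h; on this read-out higher numbers stand for weaker inhibition and lower numbers for stronger inhibition. Compound 1 carries a piperidinylmethyl group and compound 2 a triazolylmethyl group on a methoxypyridine variant of the shared core, but neither has a reported number. Compound 3, which bears the chloropyridine sulfonamide, is the only one with a result, giving 53 nM in this assay, so it stands alone and no comparison within the set is possible.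

Compound 4, `O=S(=O)(Nc1cc(-c2ccc3nccc(-c4ccc(Cn5cncn5)cc4)c3c2)cnc1Cl)c1ccc(F)cc1F`, has not yet been measured. It differs from compound 3 in one place: 1H-1,2,4-triazol-1-yl in place of dimethylamino on a saturated chain carbon bound to an aromatic carbon. Within the data shown here, no measured pair in this set shows the effect of this exchange, so nothing here tells how large the step should be.

Given that compound 3 gives 53 nM and that no other number is available, the step from compound 3 to compound 4 is expected to be small, a 1.5-fold higher number from compound 3 to compound 4 (0.18 log units; within the scatter), probably within the usual scatter. Compound 4 is therefore estimated at 80 nM in this assay, with a range from 25 nM to 300 nM.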

Compound 4, half-maximal inhibitory concentration: 340 nM
Compound 4: middle estimate off by 4.3-fold (0.63 log units), on the low side, and the stated range ends below it.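

In this assay, putting 1H-1,2,4-triazol-1-yl in place of dimethylamino on a saturated chain carbon bound to an aromatic carbon gives a 6.4-fold higher number from compound 3 to compound 4 (0.81 log units; beyond the scatter) and thereby provides the first measured sign in this set that inhibition depends on the group at this position. The exchange replaces a group with no ring by a five-membered aromatic ring with 3 hetero atoms, and this single pair cannot separate the loss of dimethylamino from the arrival of the triazole or show which feature of either group matters. Nothing available here bears on the reason for the change.

On these data alone, compound 1 and compound 2 have no reported number, so the steps involving them cannot be read, and it remains open whether the same exchange would have a similar effect on their methoxy-bearing core. As far as these compounds go, it also remains open where a diethylamino group, a morpholin-4-yl group or a carboxylic acid on the same saturated chain carbon would fall relative to compound 3 and compound 4.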